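This account rests on a few compounds, and the source may have more. Where it says the series, first, only, none or still open, it means among the compounds named here.

Working notes on the series. Compound 1 `COc1ccc(F)cc1CNCCCNc1ccnc2cc(Cc3ccc(C#N)cc3)ccc12` gives 23 10^-6 cm/s in an ADME assay for permeability, using PAMPA, with a stated time of 30 min, at pH 7.4; on this read-out higher numbers stand for higher permeability and lower numbers for lower permeability. Compound 3 `COc1cccc(CNCCCNc2ccnc3cc(Cc4ccc(C#N)cc4)ccc23)c1O` gives 23 10^-6 cm/s, and the step of no change at the digits printed from compound 1 to compound 3 (within the scatter), so compound 1 and compound 3 together sit at the bottom of the three numbers. Within the data shown here, compound 2 `CC(C)(C)c1ccc(-c2ccc3c(NCCCNCc4ccco4)ccnc3c2)cc1` gives 237 10^-6 cm/s, the highest value, but it differs from compound 1 in more than one place, so no single step is drawn to it.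

Compound 4 `COc1ccc(F)cc1CNCCCNc1ccnc2cc(CC3CCCCC3)ccc12` is the next compound for this assay. It differs from compound 1 as follows: cyclohexyl in place of 4-cyanophenyl on a saturated chain carbon bound to an aromatic carbon. Among the measured compounds shown here, no measured step touches this position; the only measured step, from compound 1 to compound 3, lies at the amine end and showed no change. Compound 2 shows only what range the series can reach. For compound 4 a moderate rise is expected, a 2.6-fold higher number from compound 1 to compound 4 (0.42 log units; beyond the scatter), with the estimate 60 10^-6 cm/s between 25 10^-6 cm/s and 150 10^-6 cm/s.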

Compound 4, apparent permeability: 23 10^-6 cm/s
Estimate against measurement, compound 4: 2.6-fold (0.42 log units) above; measured number outside the range, below it.
By their numbers in this assay, from the lowest: compounds 1, 3 and 4 (each within the scatter of the next); then compound 2.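

At this position, cyclohexyl in place of 4-cyanophenyl gives no change at the digits printed from compound 1 to compound 4 (within the scatter) in this assay. Among these compounds, the aromatic ring and the nitrile can therefore both leave this saturated chain carbon without the number moving beyond the scatter, a first reading here that adds to the flat step at the amine end.

Going by these compounds, whether an amine, a morpholine or a carboxylic acid in place of cyclohexyl would hold the number at this level stays open, as does what separates these compounds from compound 2. Nothing available gives a reason for the flat step.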